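Bromo to Methoxy on the Shared Core

The source may hold more compounds than are shown below. What is called first, only, known or untested is meant among the compounds shown, and "the series" means these compounds.

In a functional assay on HeLa cells (Homo sapiens) for inhibition, read by CCK-8 assay, with a stated time of 48 h (on this read-out higher numbers stand for weaker inhibition and lower numbers for stronger inhibition), the three measured compounds gave these numbers:
compound 1 `COc1ccc(C2=NN(C3=NC(c4ccccc4)CS3)C(c3cccc4ccccc34)C2)cc1`: 3310 nM
compound 2 `O=C1CSC(N2N=C(c3ccc(Cl)cc3)CC2c2cccc3ccccc23)=N1`: 8840 nM
compound 3 `O=C1CSC(N2N=C(c3ccc(Br)cc3)CC2c2cccc3ccccc23)=N1`: 5810 nM

Compound 3 stands second highest of the three numbers, with compound 2 and compound 1 on either side, both within the scatter of it. Compound 4 `COc1ccc(C2=NN(C3=NC(=O)CS3)C(c3cccc4ccccc34)C2)cc1` differs from compound 3 by methoxy in place of bromo on an aromatic carbon. Within the data shown here, the only measured one-place step, a 1.5-fold lower number from compound 2 to compound 3 (0.18 log units; within the scatter), swaps one halogen for another and stays within the scatter, so it gives no guide to replacing a halogen with methoxy. Compound 1 also carries methoxy, but on a different core, so its number and that of compound 3 can only be set side by side. No step beyond the scatter is therefore expected, a 1.2-fold lower number from compound 3 to compound 4 (0.07 log units; within the scatter). Compound 4 is estimated at 5000 nM, between 2000 nM and 12000 nM.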

Compound 4, half-maximal inhibitory concentration: 2540 nM
Estimate against measurement, compound 4: 2.0-fold (0.29 log units) above; measured number inside the range.
By their numbers in this assay, from the lowest: compounds 4, 1, 3 and 2 (each within the scatter of the next, the first and the last beyond it).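

Here, methoxy brings a 2.3-fold lower number from compound 3 to compound 4 (0.36 log units; beyond the scatter) and a 3.5-fold lower number from compound 2 to compound 4 (0.54 log units; beyond the scatter) in this assay and so moves the number beyond the scatter at this position, which the swap of one halogen for the other did not do. Exchanging the whole group on the amine nitrogen in a ring brings a 1.3-fold lower number from compound 1 to compound 4 (0.11 log units; within the scatter) and stays within the scatter. Nothing measured here says why methoxy differs from the halogens. From the compounds shown here alone, whether an amine, a hydroxyl or a longer chain such as ethoxy would lower the number further at this position remains open, as does whether methoxy and bromo differ in the same way on the core of compound 1.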